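A Larger Group at the Same Aromatic Carbon

The source may hold more compounds than are shown below. What is called first, only, known or untested is meant among the compounds shown, and "the series" means these compounds.

Three compounds have been measured in a functional assay on A549 cells (Homo sapiens) for antiproliferative activity, read by MTT assay, with a stated time of 72 h; a higher number here means a weaker inhibitor, a lower number a stronger inhibitor:

Compound 1, `CCN(CC)Cc1ccc(NC(=O)Nc2ccc3ncnc(Nc4cccc(C(F)(F)F)c4)c3c2)cc1`, gives 2070 nM.
Compound 2, `CN(C)Cc1ccc(NC(=O)Nc2ccc3ncnc(Nc4cccc(C(F)(F)F)c4)c3c2)cc1`, gives 1120 nM.
Compound 3, `Cc1ccc(NC(=O)Nc2ccc3ncnc(Nc4cccc(C(F)(F)F)c4)c3c2)cc1`, gives 4140 nM.

Among these three, compound 3 has the highest number, though compound 1 sits within the usual scatter of it; only compound 2 stands apart, as a 3.7-fold higher number from compound 2 to compound 3 (0.57 log units; beyond the scatter) shows. Compound 4, `CN1CCN(c2ccc(NC(=O)Nc3ccc4ncnc(Nc5cccc(C(F)(F)F)c5)c4c3)cc2)CC1`, has not yet been measured. It differs from compound 3 in one place: 4-methylpiperazin-1-yl in place of methyl on an aromatic carbon.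

Two measured steps speak to this change, since both swap a group containing nitrogen for a smaller one at the same kind of position. The step of a 2.0-fold higher number from compound 1 to compound 3 (0.30 log units; within the scatter) and the step of a 3.7-fold higher number from compound 2 to compound 3 (0.57 log units; beyond the scatter) both run toward a higher number when the nitrogen-containing group is removed, the second one beyond the scatter. Reversing that direction, by putting a larger nitrogen-containing group in place of methyl, is therefore expected to lower the number modestly, not by a great margin.

Compound 4 is thus estimated at 1500 nM in this assay, with a range from 600 nM to 4000 nM. The expected step is a 2.8-fold lower number from compound 3 to compound 4 (0.44 log units; beyond the scatter) because a 3.7-fold higher number from compound 2 to compound 3 (0.57 log units; beyond the scatter) marks the clearest measured effect of such a group.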

Compound 4, half-maximal inhibitory concentration: 2760 nM
Estimate against measurement, compound 4: 1.8-fold (0.26 log units) below; measured number inside the range.
By their numbers in this assay, from the lowest: compounds 2, 1, 4 and 3 (each within the scatter of the next, the first and the last beyond it).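

In this assay, 4-methylpiperazin-1-yl takes the place of methyl on the same aromatic carbon (a 1.5-fold lower number from compound 3 to compound 4 (0.18 log units; within the scatter)), so even this much larger group, which brings a six-membered non-aromatic ring, does not separate from methyl at this position. Set against the two amines carried on a saturated chain carbon, the result splits: the change from (dimethylamino)methyl is a real one (a 2.5-fold higher number from compound 2 to compound 4 (0.39 log units; beyond the scatter)), whereas the change from (diethylamino)methyl is not (a 1.3-fold higher number from compound 1 to compound 4 (0.12 log units; within the scatter)). A nitrogen-containing group here therefore does not by itself move the number beyond the scatter of the methyl compound; among the compounds shown, only the (dimethylamino)methyl group of compound 2 does so, and compound 1 and compound 4 go against any such general rule.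

The compounds shown leave open whether a morpholine, a piperazine without its methyl, or a 4-methylpiperazine carried on a saturated chain carbon would behave like the (dimethylamino)methyl group or like methyl. No measurement available here bears on what lies behind these differences.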